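The compounds below may be only part of what the source reports. "The series", "measured", "known", "first", "only" and "open" are said of these compounds alone.

Measured compounds in a functional assay on the whole organism with Rattus norvegicus as the target, at a dose of 1 mg/kg by the oral route; on this read-out higher numbers stand for a stronger effect at the one dose given and lower numbers for a weaker effect:

compound 1, `O=C(Nc1nn[nH]n1)c1cc(Cl)cc(-c2ccccc2)n1`, 40%
compound 2, `COc1ccc(-c2cc(Cl)cc(C(=O)Nc3nn[nH]n3)n2)cc1`, 43%
compound 3, `COc1cc(C(=O)Nc2nn[nH]n2)nc(-c2ccccc2)c1`, 62%

Compound 3 holds the highest number of the three. Among the measured compounds shown here, the only step into it, a number 22 percentage points higher from compound 1 to compound 3 (beyond the scatter), lies beyond the scatter, and against compound 2 its value is also separated by more than the scatter.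

Compound 4, `COc1cc(C(=O)Nc2nn[nH]n2)nc(-c2ccc(C(C)C)cc2)c1`, is not yet measured. It differs from compound 3 in one place: isopropyl in place of hydrogen on an aromatic carbon.

For the measured compounds named here, one measured step touches the same position of the phenyl ring: a number 3 percentage points higher from compound 1 to compound 2 (within the scatter), which stayed within the scatter when a methoxy group took the place of hydrogen there. A single step is thin ground, and isopropyl is not methoxy, but nothing in the series points to a large shift from a substituent on this ring. The expectation is therefore a step of no clear size, a number 2 percentage points lower from compound 3 to compound 4 (within the scatter), with the number of compound 4 staying close to that of compound 3.

For compound 4 in this assay the estimate is 60%, within 42% to 78%.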

Compound 4, a percentage reported as inhibition, in the whole organism at one dose (the size of the read-out at that dose, not a potency): 54%
Estimate against measurement, compound 4: 6 percentage points above, within the range that was stated.
By their numbers in this assay, from the lowest: compounds 1 and 2 (each within the scatter of the next); then compounds 4 and 3 (each within the scatter of the next).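

In this assay, isopropyl in place of hydrogen on an aromatic carbon of the six-membered aromatic ring of carbon only, para to a large group, gives a number 8 percentage points lower from compound 3 to compound 4 (within the scatter). This position therefore carries a group of 3 carbon atoms with no ring and no change beyond the scatter. Until now the position was read only through methoxy on the chloro core, as a number 3 percentage points higher from compound 1 to compound 2 (within the scatter), and the new step extends that reading to a second group on the methoxy core of compound 3; no measurement at hand accounts for either step.

Open, from the compounds shown here alone, is whether an amine, a carboxylic acid or a longer chain at this position would also stay within the scatter. Also open, going by these compounds, is whether isopropyl gives a similar step on the core of compound 1.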